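This account rests on a few compounds, and the source may have more. Where it says the series, first, only, none or still open, it means among the compounds named here.

Series notes. In a functional assay on MDA-MB-231 cells (Homo sapiens) for antiproliferative activity, read by sulforhodamine B assay, with a stated time of 48 h (a higher number here means a weaker inhibitor, a lower number a stronger inhibitor), compound 1 (`COc1ccc2nc(-c3ccc(N/C=C\C(=O)c4ccc(OC)c(O)c4)c(C)c3)sc2c1`) gives 14000 nM, compound 2 (`COc1cc(C(=O)/C=C\Nc2ccc(-c3nc4cc(OC)c(OC)c(OC)c4s3)cc2)c(Br)c(OC)c1OC`) gives 15600 nM and compound 3 (`COc1ccc2nc(-c3ccc(N/C=C\C(=O)c4ccc(OC)c(O)c4)cc3)sc2c1`) gives 18900 nM. Compound 1 thus sits within the scatter of both others. Compound 4 (`COc1ccc2nc(-c3ccc(N/C=C\C(=O)c4ccc(OC)c(F)c4)c(C)c3)sc2c1`) differs from compound 1 as follows: fluoro in place of hydroxy on an aromatic carbon. This turns 3-hydroxy-4-methoxyphenyl into 3-fluoro-4-methoxyphenyl. Going by the values given here, the only measured single-site step, a 1.4-fold higher number from compound 1 to compound 3 (0.13 log units; within the scatter), is hydrogen in place of methyl on an aromatic carbon and stays within the scatter. Among the compounds with values here, no measured step touches the hydroxy group, so the evidence is thin, and no step beyond the scatter is expected in this assay. Compound 4 is expected at 18000 nM, with an estimated range of 8000 nM to 45000 nM. The expected step is a 1.3-fold higher number from compound 1 to compound 4 (0.11 log units; within the scatter).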

Compound 4, half-maximal inhibitory concentration: 2000 nM
Compound 4: the middle estimate sits 9.0-fold (0.95 log units) above what was measured; measured number below the stated range.
By their numbers in this assay, from the lowest: compound 4; then compounds 1, 2 and 3 (each within the scatter of the next).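

Going by these compounds alone, the 3-hydroxy-4-methoxyphenyl ring gives the first change that moves beyond the scatter: in this assay, fluoro in place of hydroxy gives a 7.0-fold lower number from compound 1 to compound 4 (0.85 log units; beyond the scatter). Within the data shown here, the one earlier single-site step, hydrogen in place of methyl, stayed within the scatter. Nothing measured here accounts for the new step.

Only one replacement of the hydroxy group is shown, so an amine, chloro or plain hydrogen at this position remains open. Also open, as far as these compounds go, is whether the same change holds on compound 3, which lacks the methyl group.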